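This account rests on a few compounds, and the source may have more. Where it says the series, first, only, none or still open, it means among the compounds named here.

Of the compounds shown here, three built on one shared core have been measured in a functional assay on Ishikawa cells (Homo sapiens) for inhibition, read by MTT assay, with a stated time of 48 h; a lower number here means a stronger inhibitor, a higher number a weaker inhibitor. Compound 1 `CCOC(=O)c1c(N)sc(/N=C/c2ccc(N(C)C)cc2)c1C(=O)OCC` gives 73000 nM. Compound 2 `CCOC(=O)c1c(N)sc(/N=C/c2ccc(OC)cc2)c1C(=O)OCC` gives 108000 nM, and compound 3 `CCOC(=O)c1c(N)sc(/N=C/c2ccncc2)c1C(=O)OCC` gives 119000 nM. Compound 3 thus carries the highest of the three numbers, yet this placing is only nominal: the step of a 1.6-fold higher number from compound 1 to compound 3 (0.21 log units; within the scatter) and the step of a 1.1-fold higher number from compound 2 to compound 3 (0.04 log units; within the scatter) both lie within the scatter of repeated measurements, as does the step of a 1.5-fold higher number from compound 1 to compound 2 (0.17 log units; within the scatter). Across these three compounds, exchanging the aromatic group attached to the carbon with a double bond to nitrogen has given numbers that all sit within the scatter of one another.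

Compound 4 `CCOC(=O)c1c(N)sc(/N=C/c2ccc([N+](=O)[O-])cc2)c1C(=O)OCC` has not yet been measured. It differs from compound 3 in one place: 4-nitrophenyl in place of pyridin-4-yl on a carbon with a double bond to nitrogen. The measured steps that bear on this change are the two that also replaced the group on that same carbon, a 1.1-fold higher number from compound 2 to compound 3 (0.04 log units; within the scatter) and a 1.6-fold higher number from compound 1 to compound 3 (0.21 log units; within the scatter), and both were within the scatter. On that basis the expected step of a 1.2-fold lower number from compound 3 to compound 4 (0.08 log units; within the scatter) is none beyond the scatter, in no particular direction. Compound 4 is therefore estimated to give about 100000 nM in this assay, with a range from 50000 nM to 200000 nM.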

Compound 4, half-maximal inhibitory concentration: 141000 nM
Beside the measured number, compound 4's estimate is 1.4-fold (0.15 log units) below it; the measured number falls inside the stated range.
By their numbers in this assay, from the lowest: compounds 1, 2, 3 and 4 (each within the scatter of the next).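

In this assay, putting 4-nitrophenyl in place of pyridin-4-yl on the carbon with a double bond to nitrogen gives a step within the scatter (a 1.2-fold higher number from compound 3 to compound 4 (0.07 log units; within the scatter)), so a fourth aromatic group joins the others without separating from them. The two comparisons on the aromatic carbon agree with this: nitro in place of methoxy (a 1.3-fold higher number from compound 2 to compound 4 (0.12 log units; within the scatter)) and nitro in place of dimethylamino (a 1.9-fold higher number from compound 1 to compound 4 (0.29 log units; within the scatter)) also stay within the scatter, and the second of these, the widest step among the four compounds, still does not separate the pair. No other data are available to connect these numbers to any feature of the groups.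

Every compound shown keeps an aromatic ring on that carbon, so it remains open whether a cyclohexyl ring or a plain alkyl chain there would give a number that stands apart from these four. Also open, from the compounds shown here alone, is what would happen away from that carbon, for instance if a carboxylic acid or an amide replaced one of the two ethyl esters on the shared core.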